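Adding a Single Fluorine to Compound 3

The compounds below may be only part of what the source reports. "The series", "measured", "known", "first", "only" and "open" are said of these compounds alone.

Compound 3 `Cn1ccc2c(Oc3ccc(NC(=O)c4cc5cccnc5n(-c5ccc(C(F)(F)F)cc5Cl)c4=O)cc3)ccnc21` gives 12600 nM in a functional assay on U-87MG ATCC cells for antiproliferative activity against U-87 MG (Homo sapiens), read by MTT assay, with a stated time of 72 h (a lower number here means a stronger inhibitor, a higher number a weaker inhibitor), the highest of the three numbers seen: compound 1 `Cn1ccc2c(Oc3ccc(NC(=O)c4cc5cccnc5n(-c5ccc(F)cc5)c4=O)cc3)ccnc21` gives 2120 nM and compound 2 `Cn1ccc2c(Oc3ccc(NC(=O)c4cc5cccnc5n(-c5ccc(F)c(Cl)c5)c4=O)cc3)ccnc21` gives 2350 nM, so a 5.9-fold higher number from compound 1 to compound 3 (0.77 log units; beyond the scatter) and a 5.4-fold higher number from compound 2 to compound 3 (0.73 log units; beyond the scatter) both go beyond the scatter. Compound 4 `Cn1ccc2c(Oc3ccc(NC(=O)c4cc5cccnc5n(-c5ccc(C(F)(F)F)cc5Cl)c4=O)cc3F)ccnc21` differs from compound 3 by fluoro in place of hydrogen on an aromatic carbon. Going by the values given here, no measured step alters this same ring. The nearest guide is the single-halogen addition in a 1.1-fold higher number from compound 1 to compound 2 (0.04 log units; within the scatter), which stayed within the scatter, though on another ring. A step of that size, close to none, is therefore expected, giving a 1.1-fold lower number from compound 3 to compound 4 (0.02 log units; within the scatter) for compound 4. Compound 4 is estimated at 12000 nM in this assay, with a range from 5000 nM to 30000 nM.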

Compound 4, half-maximal inhibitory concentration: 10200 nM
Estimate against measurement, compound 4: 1.2-fold (0.07 log units) above, and the stated range covers the measured number.
By their numbers in this assay, from the lowest: compounds 1 and 2 (each within the scatter of the next); then compounds 4 and 3 (each within the scatter of the next).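

In this assay, fluoro in place of hydrogen on an aromatic carbon of this six-membered aromatic ring of carbon only gives a 1.2-fold lower number from compound 3 to compound 4 (0.09 log units; within the scatter), a step within the scatter. Going by these compounds alone, this ring stayed the same across the earlier compounds, and now it is seen to take a single fluorine with no change beyond the scatter. No measurement here explains why the step is so small.

Going by these compounds, whether an amine or a methoxy group at this position would behave the same remains open. So does whether fluoro here would have a similarly small effect with the aryl groups of compound 1 and compound 2.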